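A Longer Acyl Chain on a Weakly Active Amide

The source may hold more compounds than are shown below. What is called first, only, known or untested is meant among the compounds shown, and "the series" means these compounds.

The shared core of compound 1 `O=C(Nc1ccccc1O)C1CCc2ccccc2N1C(=O)c1ccc(Cl)cc1` carries an aryl amide and an acyl group on the ring nitrogen. In a functional assay on NCI-H23 cells (Homo sapiens) for cytotoxicity, read by sulforhodamine B assay, with a stated time of 72 h (a lower number here means a stronger inhibitor of growth, a higher number a weaker inhibitor of growth), compound 1 gives 19200 nM. Compound 2 `CC(=O)N1c2ccccc2CCC1C(=O)Nc1cc(C(F)(F)F)cc(C(F)(F)F)c1` reaches only the limit of this assay, at > 70000 nM, which is a limit and not a number. Compound 3 `CCCC(=O)N1c2ccccc2CCC1C(=O)Nc1ccccc1C(F)(F)F` likewise stands at the limit of this assay, > 70000 nM, again a limit rather than a number. Compound 3 therefore shows no measurable growth inhibition, and the limit of > 70000 nM in this assay, at which 2 of the 3 values shown sit, marks where two of the three values shown sit.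

Compound 4 `CCCCCCCCC(=O)N1c2ccccc2CCC1C(=O)Nc1ccccc1C(F)(F)F` differs from compound 3 by pentyl in place of hydrogen on a saturated chain carbon, three bonds along the chain from a carbonyl carbon. No step between measured compounds is shown, so the size and direction of this change cannot be read from the data. The expected step of an at least 1.1-fold lower number from compound 3 to compound 4 (0.06 log units; that floor lies within the scatter) is estimated to be small, with no clear direction beyond the scatter, and most likely the assay again reports only a limit. Compound 4 is expected to give about 60000 nM, within a range from 15000 nM to 250000 nM.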

Compound 4, concentration for 50% growth inhibition: 4220 nM
For compound 4 the middle estimate is 14-fold (1.15 log units) above the measured one; the measured number lies below the stated range.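

In this assay, pentyl in place of hydrogen on a saturated chain carbon, three bonds along the chain from a carbonyl carbon, gives an at least 16-fold lower number from compound 3 to compound 4 (1.21 log units; beyond the scatter). This shows that the acyl chain on the ring nitrogen is not a silent position: extending it here takes the compound from the limit of the assay to a measurable number. The step can be stated only as a bound, since its starting point is a limit and not a number, one shared with compound 2: the limit of > 70000 nM in this assay, at which 2 of the 4 values shown sit.

With a single step along this chain, the compounds shown do not tell whether growth inhibition changes steadily with chain length or whether a still longer chain would go further. They also leave open whether a carboxylic acid or an amine at the chain end would keep the effect.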